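This account rests on a few compounds, and the source may have more. Where it says the series, first, only, none or still open, it means among the compounds named here.

Measured so far in an assay on Huh-7 cells for agonist activity at Bile acid receptor (Homo sapiens), read by a luciferase reporter; a higher number here means that more compound is needed for the effect, a lower number that less compound is needed:
- compound 1 `CCC(CC)n1c(-c2ccc(OCc3c(-c4c(Cl)cccc4Cl)noc3C(C)C)cc2)nc2ccc(C(=O)O)cc21` gives 0.8 nM
- compound 2 `CC(C)Cn1c(-c2ccc(OCc3c(-c4c(Cl)cccc4Cl)noc3C(C)C)cc2)nc2ccc(C(=O)O)cc21` gives 5.26 nM

Compound 2 stands with the highest number of the two; its nearest neighbour is compound 1, reached by a 6.6-fold higher number from compound 1 to compound 2 (0.82 log units; beyond the scatter) when read in reverse. Compound 3 `CC(C)c1onc(-c2c(Cl)cccc2Cl)c1COc1ccc(-c2nc3ccc(C(=O)O)cc3n2C2CCCCC2)cc1` is not yet measured. The change from compound 2 to compound 3 is cyclohexyl in place of isobutyl on an aromatic nitrogen. Among the measured compounds shown here, the only measured step that bears on this position is a 6.6-fold higher number from compound 1 to compound 2 (0.82 log units; beyond the scatter), a modest step that shows the number on this nitrogen to be sensitive to the group placed there. For the measured compounds named here, with only one such step, the direction for a six-membered ring at the same site cannot be read with confidence; the expectation is that compound 3 lands between the two measured values, nearer to compound 1 than to compound 2. The estimated step of a 2.9-fold lower number from compound 2 to compound 3 (0.47 log units; beyond the scatter) is thus expected toward a lower number. For compound 3 the estimate is 1.8 nM, within 0.5 nM to 7 nM.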

Compound 3, half-maximal effective concentration: 4.21 nM
Beside the measured number, compound 3's estimate is 2.3-fold (0.37 log units) below it; the measured number falls inside the stated range.
By their numbers in this assay, from the lowest: compound 1; then compounds 3 and 2 (each within the scatter of the next).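

In this assay, replacing isobutyl with cyclohexyl on the aromatic nitrogen gives a 1.2-fold lower number from compound 2 to compound 3 (0.10 log units; within the scatter), so the two groups are not told apart here, even though a six-membered non-aromatic ring enters and the group grows from 4 to 6 heavy atoms. Replacing pentan-3-yl with cyclohexyl gives a 5.3-fold higher number from compound 1 to compound 3 (0.72 log units; beyond the scatter), which leaves compound 1, with pentan-3-yl, as the only one of the three set apart, with the lowest number. Nothing measured here accounts for this difference.

The compounds shown leave open how a cyclopentyl ring, a phenyl ring or a straight pentyl chain on this aromatic nitrogen would read. They also leave open whether the low number of compound 1 is particular to pentan-3-yl or extends to other groups at this site.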